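Chlorine for trifluoromethyl on the urea aryl ring

The source may report more compounds than this note shows. Statements on the series, on what has been measured and on what is new or still open speak of the compounds shown alone.

Measured so far, in a functional assay on RPMI-8226 cells (Homo sapiens) for inhibition, read by sulforhodamine B assay, with a stated time of 48 h; a higher number here means that more compound is tolerated, a lower number that less compound is tolerated:
compound 1, `COc1cc2cc(Oc3ccc(NC(=O)Nc4cccc(C(F)(F)F)c4)cc3)c(C)nc2cc1OC`, gives > 50000 nM.
compound 2, `COc1cc2cc(Oc3ccc(NC(=O)Nc4ccc(Cl)c(C(F)(F)F)c4)cc3)c(C)nc2cc1OC`, gives > 32500 nM.

Both numbers are limits of this assay, not measured values. For compound 1 the value > 50000 nM is a limit, as in the limit of > 50000 nM in this assay, at which 1 of the 2 values shown sits. For compound 2 the value > 32500 nM is likewise a limit, as in the limit of > 32500 nM in this assay, at which 1 of the 2 values shown sits. The step that the two limits leave unreadable from compound 1 to compound 2 is therefore not readable; all that the two entries show is that neither compound 1 nor compound 2 is tolerated within the tested range to any extent that this assay can quantify.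

Compound 3, `COc1cc2cc(Oc3ccc(NC(=O)Nc4ccc(Cl)c(Cl)c4)cc3)c(C)nc2cc1OC`, is the next member. It differs from compound 2 by chloro in place of trifluoromethyl on an aromatic carbon. No measured step in this assay bears directly on this change, since the only step shown, from compound 1 to compound 2, is itself hidden by the two limits. The shared core and the urea linker are unchanged, and both neighbours sit at a limit; the expectation is that compound 3 behaves the same way. The step that the limit leaves unreadable from compound 2 to compound 3 is expected to be none beyond the scatter. For compound 3 the estimated value in this assay is 40000 nM, with a range from 15000 nM to 100000 nM, most likely reported again as a limit.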

Compound 3, concentration lethal to 50% of the cells: > 100000 nM
Compound 3 gave a limit, no number; the forecaster's own chance of this, stated with the estimate: 80%; middle value at least 2.5-fold (0.39 log units) from the limit.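

Compound 3, like compound 1 and compound 2, gives only a limit in this assay, so neither the step from compound 2 to compound 3 nor the step from compound 1 to compound 3 can be read. The compounds shown leave open whether the three differ at all in this read-out, and by how much.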